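The compounds below may be only part of what the source reports. "The series", "measured", "known", "first", "only" and "open" are said of these compounds alone.

Compound 1 `Cc1cccc(C)c1-c1cccc(COc2ccc(CCC(=O)O)cn2)c1` is the reference point of this set. In a functional assay on CHO cells for agonist activity at Free fatty acid receptor 1 (Homo sapiens), read by calcium flux (on this read-out higher numbers stand for an effect only at larger amounts of compound and lower numbers for an effect already at smaller amounts), compound 1 gives 3.5 nM, the lowest of the three numbers recorded. Compound 2 `Cc1cccc(C)c1-c1cccc(COc2ccc(CCC(=O)O)s2)c1` carries the chain on a different ring; in this assay compound 2 gives 52 nM, and the two values differ well beyond the scatter. Compound 3 `Cc1cc(OCc2cccc(-c3c(C)cccc3C)c2)ncc1CCC(=O)O` adds a methyl to the aromatic ring of compound 1; in this assay compound 3 gives 9.3 nM, so that a 2.7-fold higher number from compound 1 to compound 3 (0.42 log units; beyond the scatter).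

Compound 4 `Cc1cccc(C)c1-c1cccc(COc2ccc(C(C)CC(=O)O)cn2)c1` is the next member. Its change from compound 1 is methyl in place of hydrogen on a saturated chain carbon bound to an aromatic carbon and a saturated chain carbon. For the measured compounds named here, no measured step bears directly on this place: the only one-point step recorded, from compound 1 to compound 3, concerns a methyl on an aromatic carbon rather than on the chain, and the gap between compound 1 and compound 2 reflects a change of ring, not of chain. On this basis compound 4 is expected to stay close to compound 1, with any shift in this assay most likely of modest size and in an uncertain direction, and the expected step is a 1.4-fold higher number from compound 1 to compound 4 (0.15 log units; within the scatter). The estimate for compound 4 in this assay is therefore 5 nM, with a range from 1.5 nM to 15 nM.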

Compound 4, half-maximal effective concentration: 10 nM
Beside the measured number, compound 4's estimate is 2.0-fold (0.30 log units) below it, and the stated range covers the measured number.
By their numbers in this assay, from the lowest: compound 1; then compounds 3 and 4 (each within the scatter of the next); then compound 2.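

Methyl in place of hydrogen on a saturated chain carbon bound to an aromatic carbon and a saturated chain carbon is the first change in this series made on the chain itself, and in this assay it gives a 2.9-fold higher number from compound 1 to compound 4 (0.46 log units; beyond the scatter) as a modest step beyond the scatter. Set against a 2.7-fold higher number from compound 1 to compound 3 (0.42 log units; beyond the scatter) on an aromatic carbon, this shows that a single added methyl at either of these two places moves the number up from that of compound 1, and that neither place gives a lower number in these compounds. No measured evidence on the compounds explains the rise seen with the 2-carboxyethyl to 1-(carboxymethyl)ethyl change.

The compounds shown leave open whether the step at this chain carbon grows or shrinks with a larger or different group, such as an ethyl, a hydroxyl or a second methyl on the same carbon. They also leave open whether a fluorine in place of the same hydrogen would stay within the scatter of compound 1 or move away from it.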